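From Dihydroxyphenyl to Bromophenyl on a Carbonyl Carbon

The source may hold more compounds than are shown below. What is called first, only, known or untested is meant among the compounds shown, and "the series" means these compounds.

In a functional assay on cells (Erythrocyte, Rattus norvegicus) for inhibition, read by hemolysis, with a stated time of 1 h (a lower number here means a stronger inhibitor, a higher number a weaker inhibitor), compound 1 (`COc1cc(OC)c(-c2cc(=O)c3cc(Cl)ccc3o2)cc1OC`) gives 2.13 ug/mL and compound 3 (`COc1cc(OC)c(C(=O)/C=C/c2cc(OC)c(OC)cc2OC)c(OC)c1`) gives 2.13 ug/mL as half-maximal inhibitory concentrations. Compound 2 (`COc1cc(OC)c(OC)cc1/C=C/C(=O)c1ccc(O)cc1O`) gives 2.37 ug/mL and so stands level with both of them, as its gaps to each lie within the usual scatter of repeated measurements. In other words, these three readings cannot be told apart.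

Compound 4 (`COc1cc(OC)c(OC)cc1/C=C/C(=O)c1ccc(Br)cc1`) has not been measured yet. It carries 4-bromophenyl in place of 2,4-dihydroxyphenyl on a carbonyl carbon. Both groups are six-membered aromatic rings of carbon only, but the hydrogen-bond donors and acceptors leave with the old group.

Among the compounds with values here, no measured pair of compounds shows a change in one place, so the data offer no direct guide to this swap. Within the data shown here, the only hint is that compound 2 at 2.37 ug/mL sits level with compound 1 at 2.13 ug/mL and compound 3 at 2.13 ug/mL despite their different structures, so no step beyond the scatter is expected. The estimated change is a 1.1-fold higher number from compound 2 to compound 4 (0.02 log units; within the scatter) and would stay within the scatter. The estimated value of compound 4 in this assay is 2.5 ug/mL with an expected range from 1.1 ug/mL to 5.5 ug/mL until a measurement settles it.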

Compound 4, half-maximal inhibitory concentration: 2.3 ug/mL
Compound 4: the middle estimate sits 1.1-fold (0.04 log units) above what was measured, and the stated range covers the measured number.
By their numbers in this assay, from the lowest: compounds 1, 3, 4 and 2 (each within the scatter of the next).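

Within the data shown here, this is the only step in the set that changes a single place, and in this assay putting 4-bromophenyl in place of 2,4-dihydroxyphenyl on a carbonyl carbon gives a 1.0-fold lower number from compound 2 to compound 4 (0.01 log units; within the scatter). At this place, then, both oxygen atoms can leave with their hydrogen-bond donors and acceptors, and a bromine can enter, without a change that can be told from the scatter. Nothing shown here explains why the reading stays level.

One level step covers only these two groups, so it cannot say whether the reading would hold for a different kind of group on the carbonyl carbon, such as an aminophenyl, a carboxyphenyl or an open alkyl chain in place of the ring. The two hydroxyl groups and the bromine also changed together in this swap, so a plain phenyl group or a phenyl group with a single hydroxyl would be needed to show whether each change has no effect of its own or whether two separate effects happen to cancel.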